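This account rests on a few compounds, and the source may have more. Where it says the series, first, only, none or still open, it means among the compounds named here.

Compound 1 `CCCCCn1cc(S(=O)(=O)Nc2ccc(CC)cc2)c2cccnc21` and compound 2 `CCc1ccc(NS(=O)(=O)c2cn(Cc3ccccn3)c3ncccc23)cc1` share one core and differ only on a saturated chain carbon bound to an aromatic nitrogen. In an assay on FRT cells for positive allosteric modulation of Cystic fibrosis transmembrane conductance regulator variant W1282X (Homo sapiens) (on this read-out lower numbers stand for an effect already at smaller amounts and higher numbers for an effect only at larger amounts of compound), compound 1 gives 1000 nM, and in this assay compound 2 gives 600 nM, the lower of the two numbers; the step of a 1.7-fold lower number from compound 1 to compound 2 (0.22 log units; within the scatter) does not, however, exceed the scatter, so the two compounds cannot be ordered.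

Compound 3 `CCc1ccc(NS(=O)(=O)c2cn(Cc3ccccc3C#N)c3ncccc23)cc1` has not been measured. It differs from compound 2 by 2-cyanophenyl in place of pyridin-2-yl on a saturated chain carbon bound to an aromatic nitrogen. Among the compounds with values here, the only measured step at that position, a 1.7-fold lower number from compound 1 to compound 2 (0.22 log units; within the scatter), bears on the change, and it was within the scatter even though it exchanged a butyl chain for an aromatic ring. Within the data shown here, with no larger step seen at this position, no move beyond the scatter is expected in this assay, and the estimated step is a 1.1-fold higher number from compound 2 to compound 3 (0.03 log units; within the scatter). For compound 3 the expected value in this assay is therefore 650 nM, with a range from 250 nM to 1700 nM.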

Compound 3, half-maximal effective concentration: 700 nM
Compound 3: middle estimate off by 1.1-fold (0.03 log units), on the low side, within the range that was stated.
By their numbers in this assay, from the lowest: compounds 2, 3 and 1 (each within the scatter of the next).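

In this assay the place on a saturated chain carbon bound to an aromatic nitrogen now holds a second aromatic group with no readable move: the change to 2-cyanophenyl gives a 1.2-fold higher number from compound 2 to compound 3 (0.07 log units; within the scatter) when it replaces pyridin-2-yl and a 1.4-fold lower number from compound 1 to compound 3 (0.15 log units; within the scatter) when it replaces butyl. Butyl, pyridin-2-yl and 2-cyanophenyl therefore cannot be ordered here, and bringing in a nitrile with its triple bond outside aromatic rings yields no step beyond the scatter. Nothing at hand explains why these three groups read alike.

As far as these compounds go, whether any group at this place can move the number beyond the scatter remains open. A carboxylic acid, an amine or a much longer chain on that carbon could show whether the tolerance seen with these three groups extends further.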